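Trifluoromethoxy for Bromo in a Vero Cell Tolerance Series

The source may report more compounds than this note shows. Statements on the series, on what has been measured and on what is new or still open speak of the compounds shown alone.

Compound 1 `COc1nc(-c2ccc(Br)cc2)ccc1[C@@H](c1ccccc1)[C@@](O)(CCN(C)C)c1cccc2ccccc12` was tested in a toxicity assay on Vero cells (Chlorocebus sabaeus) for cytotoxicity; a higher number here means that more compound is tolerated, a lower number that less compound is tolerated. In this assay compound 1 gives only a limit, > 50 ug/mL. Compound 2 `COc1ncc(-c2ccccc2)cc1[C@@H](c1ccccc1)[C@@](O)(CCN(C)C)c1cc(F)ccc1F` also gives only a limit in this assay, > 50 ug/mL. Compound 1 thus stands at the limit of > 50 ug/mL in this assay, at which 2 of the 2 values shown sit, with no number of its own. Compound 3 `COc1nc(-c2ccc(OC(F)(F)F)cc2)ccc1[C@@H](c1ccccc1)[C@@](O)(CCN(C)C)c1cccc2ccccc12` differs from compound 1 by trifluoromethoxy in place of bromo on an aromatic carbon, the same change read one bond further out being 4-bromophenyl to 4-(trifluoromethoxy)phenyl. For the measured compounds named here, no measured step between compounds is available to size this change, so the step that the limit leaves unreadable from compound 1 to compound 3 is expected to be none beyond the scatter. Compound 3 is therefore estimated at 60 ug/mL, within a range of 30 ug/mL to 120 ug/mL.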

Compound 3, half-maximal cytotoxic concentration: > 50 ug/mL
Compound 3: only a limit was reported; the forecaster's own chance of this, stated with the estimate: 75%; the middle value does not contradict the limit.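

No step from compound 1 to compound 3 can be read in this assay, because each gives only a limit: the limit of > 50 ug/mL in this assay, at which 3 of the 3 values shown sit.

On these data alone, whether trifluoromethoxy in place of bromo changes tolerance in this assay at all remains open.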